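The source may report more compounds than this note shows. Statements on the series, on what has been measured and on what is new or still open speak of the compounds shown alone.

Measured compounds:
compound 1 `COc1cccc(OC)c1OCCNCCOc1ccccc1OCc1cccc(Cl)c1` — 0.251 nM
compound 2 `COc1cccc(OC)c1OCCNCCOc1ccccc1OCc1ccccc1C` — 1.59 nM
compound 3 `COc1cccc(OC)c1OCCNCCOc1ccccc1OCc1cccc(C)c1` — 0.398 nM

In an assay on CHO cells for displacement of a labelled ligand from Alpha-1A adrenergic receptor (Homo sapiens) (a lower number here means a stronger inhibitor, a higher number a weaker inhibitor), compound 1 holds the lowest of the three numbers. The step of a 1.6-fold higher number from compound 1 to compound 3 (0.20 log units; within the scatter) stays within the scatter, whereas a 6.3-fold higher number from compound 1 to compound 2 (0.80 log units; beyond the scatter) and a 4.0-fold lower number from compound 2 to compound 3 (0.60 log units; beyond the scatter) both go beyond it. Compound 4 `COc1cccc(OC)c1OCCNCCOc1ccccc1OCc1cccc([N+](=O)[O-])c1` is not yet measured; it differs from compound 1 as follows: nitro in place of chloro on an aromatic carbon. Among the compounds with values here, the nearest measured step is the one at the same aromatic carbon, a 1.6-fold higher number from compound 1 to compound 3 (0.20 log units; within the scatter), which was within the scatter; no measured compound carries a nitro group, so the bearing of that step is indirect. A small step, if any, is expected in this assay. Compound 4 is therefore estimated at 0.5 nM, in the range 0.15 nM to 1.6 nM. This corresponds to an expected step of a 2.0-fold higher number from compound 1 to compound 4 (0.30 log units; within the scatter).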

Compound 4, inhibition constant: 0.316 nM
The estimate for compound 4 lay 1.6-fold (0.20 log units) above the measured number; low and high end bracket the measured number.
By their numbers in this assay, from the lowest: compounds 1, 4 and 3 (each within the scatter of the next); then compound 2.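

In this assay, nitro, with its 3 heavy atoms and 2 hydrogen-bond acceptors, replaces the single chlorine on this aromatic carbon with only a 1.3-fold higher number from compound 1 to compound 4 (0.10 log units; within the scatter) and no step beyond the scatter. It also replaces methyl at this carbon with just a 1.3-fold lower number from compound 3 to compound 4 (0.10 log units; within the scatter), so chloro, methyl and nitro all lie within the scatter of one another here, whereas a 5.0-fold lower number from compound 2 to compound 4 (0.70 log units; beyond the scatter) shows that the gap to the 2-methylphenyl compound remains beyond it. No available evidence accounts for this result. From the compounds shown here alone, whether an amine or a carboxylic acid on this aromatic carbon would also stay within the scatter remains open.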